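Pyridine Swap on a Shared Thioether Side Chain

The compounds below may be only part of what the source reports. "The series", "measured", "known", "first", "only" and "open" are said of these compounds alone.

Compound 1 `CC(Sc1nc2c(cnn2C)c(=O)n1-c1ccccc1)c1ccccn1` and compound 3 `CC(Sc1nc2c(cnn2C)c(=O)n1-c1ccccc1)c1cccnc1` share one core and differ only in the ring carried on the saturated chain carbon. In an assay on isolated protein for inhibition of aldehyde dehydrogenase 1A1 (Homo sapiens) (on this read-out higher numbers stand for weaker inhibition and lower numbers for stronger inhibition), compound 1 gives 242 nM, and compound 3 gives 139 nM. The change between them is pyridin-3-yl in place of pyridin-2-yl on a saturated chain carbon bound to a saturated chain carbon and a sulfur, and it made a step of a 1.7-fold lower number from compound 1 to compound 3 (0.24 log units; within the scatter). Compound 2 `CC(Sc1nc2nn(C3COC3)cc2c(=O)n1-c1ccccc1)c1ccccn1` carries a different core; the difference between its core and that of compound 1 is not broken down here. In this assay compound 2 gives 68 nM, the lowest of the three numbers. Compound 4 `CC(Sc1nc2nn(C3COC3)cc2c(=O)n1-c1ccccc1)c1cccnc1` stands to compound 2 as compound 3 stands to compound 1: the change is pyridin-3-yl in place of pyridin-2-yl on a saturated chain carbon bound to a saturated chain carbon and a sulfur, the same change at the same place. For compound 4 a step of a 1.7-fold lower number from compound 2 to compound 4 (0.23 log units; within the scatter) from compound 2 is expected, beside the earlier one. This rests on the earlier step from compound 1 to compound 3, a 1.7-fold lower number from compound 1 to compound 3 (0.24 log units; within the scatter), which lay within the scatter and gives no reason to expect a larger step on the new core. Compound 4 is therefore estimated at 40 nM, with a range from 18 nM to 90 nM.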

Compound 4, half-maximal inhibitory concentration in the aldehyde dehydrogenase 1A1 assay: 118 nM
Compound 4: the middle estimate sits 3.0-fold (0.47 log units) below what was measured; the measured number lies above the stated range.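

In the aldehyde dehydrogenase 1A1 assay, the change from pyridin-2-yl to pyridin-3-yl on the core of compound 2 gave a 1.7-fold higher number from compound 2 to compound 4 (0.24 log units; within the scatter), and although each step alone lies within the scatter, the two steps on the two cores do not agree: the same change on two cores in the aldehyde dehydrogenase 1A1 assay, a 1.7-fold lower number (0.24 log units; within the scatter) from compound 1 to compound 3 and a 1.7-fold higher number (0.24 log units; within the scatter) from compound 2 to compound 4, 3.0-fold (0.48 log units) apart, beyond the scatter of two such steps This shows that, in this series, the step seen on the core of compound 1 did not carry over to the core of compound 2, though a single pair on each core cannot show why the steps part or give a rule for any other core. On the core of compound 2, the same change also shifted the read-out in a physicochemical assay for solubility, using the shake flask method, in phosphate buffer, with a stated time of 24 h, at pH 7.4 (on this read-out higher numbers stand for higher solubility and lower numbers for lower solubility), where compound 2 gives 60000 nM and compound 4 gives 189000 nM: the measured solubility of compound 2, 60000 nM, and of compound 4, 189000 nM, a 3.2-fold higher number (0.50 log units; beyond the scatter)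

Going by these compounds, it remains open whether a matching step in the physicochemical assay would appear on the core of compound 1, and which part of the difference between the two cores goes with the mismatch in the aldehyde dehydrogenase 1A1 assay. On these data alone, it is also open how either core would respond if a phenyl or a morpholine took the place of the pyridine ring on the same chain carbon.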